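The source may hold more compounds than are shown below. What is called first, only, known or untested is meant among the compounds shown, and "the series" means these compounds.

The shared core of compound 2 `O=C(CCCCCCc1cccs1)N1CCCC1` carries a thiophen-2-yl group at the far end of its chain. Going by the values given here, in an assay on HEK293 cells for inhibition of N-acylethanolamine-hydrolyzing acid amidase (Rattus norvegicus), read by LC-MS, with a stated time of 30 min (on this read-out lower numbers stand for stronger inhibition and higher numbers for weaker inhibition), compound 2 gives 14100 nM, the only plain number among the values recorded here. Its companion compound 1 `O=C(CCCCCCc1cccnc1)N1CCCC1` carries pyridin-3-yl in the same place. In this assay compound 1 reaches only a limit of the assay, > 100000 nM. Among the compounds with values here, the one measured step, an at least 7.0-fold lower number from compound 1 to compound 2 (0.85 log units; beyond the scatter), therefore rests on the limit of > 100000 nM in this assay, at which 1 of the 2 values shown sits, and can be read only as a lower bound on its size.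

Compound 3 `O=C(CCCCCCc1ccsc1)N1CCCC1` differs from compound 2 by thiophen-3-yl in place of thiophen-2-yl on a saturated chain carbon, six bonds along the chain from a carbonyl carbon. Within the data shown here, no measured step compares these two thiophene isomers: the single step recorded sets a different ring, pyridin-3-yl, against thiophen-2-yl, so it bears on the change from compound 2 to compound 3 only loosely, by showing that the ring at this chain position can matter. One would expect the shift of the attachment point within the same ring to produce no step beyond the scatter in this assay, that is an estimated 1.1-fold higher number from compound 2 to compound 3 (0.03 log units; within the scatter). Compound 3 is therefore estimated at 15000 nM in this assay, within a range from 4000 nM to 60000 nM.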

Compound 3, half-maximal inhibitory concentration: 13200 nM
Estimate against measurement, compound 3: 1.1-fold (0.06 log units) above; measured number inside the range.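

In this assay the shift from thiophen-2-yl to thiophen-3-yl on a saturated chain carbon, six bonds along the chain from a carbonyl carbon, gives a 1.1-fold lower number from compound 2 to compound 3 (0.03 log units; within the scatter) and so does not separate the two thiophene isomers at this position. The gap to pyridin-3-yl holds for the new isomer too, with an at least 7.5-fold lower number from compound 1 to compound 3 (0.87 log units; beyond the scatter) and thus is not tied to a single attachment point on the thiophene ring. The size of that step can be read only as a lower bound, since it rests on a limit: the limit of > 100000 nM in this assay, at which 1 of the 3 values shown sits.

The compounds shown leave open whether a phenyl group, a furan-2-yl group or another pyridine isomer at the same place would stand with the two thiophene compounds or with compound 1. On these data alone, they also leave open how a shorter or longer chain would alter the standing of either thiophene isomer, and the true size of the gap to compound 1 stays unknown.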